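The source may hold more compounds than are shown below. What is called first, only, known or untested is meant among the compounds shown, and "the series" means these compounds.

Measured so far in a functional assay on NSO cells (Mus musculus) for antiproliferative activity, read by CellTiter-Glo, with a stated time of 72 h; on this read-out lower numbers stand for stronger inhibition and higher numbers for weaker inhibition:
- compound 1 `Nc1cc(COc2ccc3nc(NC4CCCCC4)sc3c2)ccn1` gives 18800 nM
- compound 2 `Clc1cnccc1COc1ccc2nc(NC3CCCCC3)sc2c1` gives 15000 nM

Compound 2 holds no separate place on these two numbers, which lie within the scatter of each other. Compound 3 `Nc1nccc(COc2ccc3nc(NC4CCCCC4)sc3c2)c1Cl` differs from compound 2 by amino in place of hydrogen on an aromatic carbon, which turns 3-chloropyridin-4-yl into 2-amino-3-chloropyridin-4-yl. For the measured compounds named here, no measured step adds amino while chloro stays. Going by the values given here, the only step with any bearing is a 1.3-fold lower number from compound 1 to compound 2 (0.10 log units; within the scatter), an exchange of one pyridinyl group for the other, so it is weak evidence. Among the compounds with values here, with that step as the sole guide, no change beyond the scatter is expected in this assay, and the estimated change is a 1.3-fold lower number from compound 2 to compound 3 (0.10 log units; within the scatter) on this read-out. For compound 3 the estimated value is 12000 nM, with an expected range of 3000 nM to 30000 nM on the same read-out.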

Compound 3, half-maximal inhibitory concentration: 41700 nM
Compound 3: the middle estimate sits 3.5-fold (0.54 log units) below what was measured; measured number outside the range, above it.
By their numbers in this assay, from the lowest: compounds 2 and 1 (each within the scatter of the next); then compound 3.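

In this assay, amino in place of hydrogen on the aromatic carbon next to the ring nitrogen and ortho to a chloro group gives a 2.8-fold higher number from compound 2 to compound 3 (0.44 log units; beyond the scatter), so with chloro present this position does not take amino without a loss. Chloro in place of hydrogen gives a 2.2-fold higher number from compound 1 to compound 3 (0.35 log units; beyond the scatter), so 2-amino-3-chloropyridin-4-yl stands apart from both 2-aminopyridin-4-yl and 3-chloropyridin-4-yl, which lie within the scatter of each other. Nothing measured here accounts for this modest loss.

On these data alone, whether the loss is particular to amino, or would also follow a methylamino, hydroxyl or methyl group at this position, remains open. Also open, as far as these compounds go, is whether it depends on the chloro group, which a fluoro or methyl group in its place could test.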